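The source may hold more compounds than are shown below. What is called first, only, known or untested is meant among the compounds shown, and "the series" means these compounds.

Compound 1 `CC1(COc2ccc(OC(F)(F)F)cc2)Cn2cc([N+](=O)[O-])nc2O1` gives > 64000 nM (a limit)
Compound 2 `C[C@]1(COc2ccc(OC(F)(F)F)cc2)Cn2cc([N+](=O)[O-])nc2O1` gives > 64000 nM (a limit)

In an ADME assay on MRC5 cells (Homo sapiens) for cytotoxicity, read by fluorescence, with a stated time of 72 h (a higher number here means a weaker inhibitor, a lower number a stronger inhibitor), compound 2 stands at > 64000 nM as a limit of the assay and not a number. Compound 1 likewise gives > 64000 nM as a limit. For the measured compounds named here, the position of the series so far is the limit of > 64000 nM in this assay, at which 2 of the 2 values shown sit, and nothing finer can be read from it.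

Compound 3 `C[C@@]1(COc2ccc(OC(F)(F)F)cc2)Cn2cc([N+](=O)[O-])nc2O1` differs from compound 2 by the two compounds have the same atoms and bonds and differ only in configuration as drawn: 1 of 1 stereo elements differ; a stereocentre at a saturated ring carbon is drawn R in compound 2 and S in compound 3 in that a stereocentre at a saturated ring carbon is drawn R in compound 2 and S in compound 3.

Going by the values given here, the one measured step bearing on this is a step that the two limits leave unreadable from compound 1 to compound 2 and it concerns the fact that one of compounds 1 and 2 is drawn with a defined configuration and the other without, at the place where they differ as the only difference. With no readable size behind it, no direction can be assigned in this assay and no step beyond the scatter is expected. The estimated change is a number no higher from compound 2 to compound 3 (the limit leaves the size open) and it is expected to stay within the scatter. For compound 3 the expected value is 64000 nM with an estimated range from 40000 nM to 80000 nM and a report at the limit is likely.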

Compound 3, half-maximal inhibitory concentration: > 64000 nM
Compound 3 gave a limit, no number; the forecaster's own chance of this, stated with the estimate: 85%; the middle value sits exactly at the limit.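

No new step can be read among compound 1, compound 2 and compound 3, as each result is a limit and not a number: the limit of > 64000 nM in this assay, at which 3 of the 3 values shown sit.

As far as these compounds go, whether compound 2 and compound 3, drawn R and S at the saturated ring carbon, truly differ in this assay stays open.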